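Fluoro to methoxy in a series known only by limits

The compounds below may be only part of what the source reports. "The series", "measured", "known", "first", "only" and "open" are said of these compounds alone.

Compound 1 `COc1ccc(C(=O)CSc2nc(Cc3c(F)cccc3Cl)c(C)c(=O)[nH]2)cc1`: > 12000 nM
Compound 2 `CCc1c(Cc2c(F)cccc2Cl)nc(SCC(=O)c2ccc(F)cc2)[nH]c1=O`: > 57000 nM

In an ADME assay on MT4 cells (Homo sapiens) for cytotoxicity, read by MTT assay (a higher number here means that more compound is tolerated, a lower number that less compound is tolerated), compound 2 is reported only as a limit, > 57000 nM. Compound 1 is also reported only as a limit, > 12000 nM. For the measured compounds named here, the series therefore holds no exact value so far, and neither limit fixes an order between the two compounds.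

Compound 3 `CCc1c(Cc2c(F)cccc2Cl)nc(SCC(=O)c2ccc(OC)cc2)[nH]c1=O` has 4-methoxyphenyl where compound 2 has 4-fluorophenyl: methoxy in place of fluoro on an aromatic carbon, para to a large group (methoxy in place of fluoro on an aromatic carbon). Going by the values given here, no measured step exists to scale this change, so the expectation is loose. A modest downward step is expected in this assay, and another limit is the more likely report. The expected change is an at least 1.9-fold lower number from compound 2 to compound 3 (0.27 log units; that floor lies within the scatter). For compound 3 the estimated value is 30000 nM, with an expected range of 8000 nM to 110000 nM.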

Compound 3, half-maximal cytotoxic concentration: > 11000 nM
Compound 3: a limit, no number (the forecaster's own chance of this, stated with the estimate: 65%); the middle value does not contradict the limit.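

In this assay, compound 3 is reported only as a limit, > 11000 nM. Compounds 1, 2 and 3 are all known only by limits, so the steps from compound 2 and compound 1 to compound 3 cannot be read. As far as these compounds go, whether either single change shifts the tolerated concentration remains open.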